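Chloro to bromo exchange in two related cores

The source may hold more compounds than are shown below. What is called first, only, known or untested is meant among the compounds shown, and "the series" means these compounds.

Measured in a functional assay on BGC-823 cells (Homo sapiens) for inhibition, read by CCK-8 assay, with a stated time of 48 h; a lower number here means a stronger inhibitor, a higher number a weaker inhibitor:
compound 1 `O=C1CSC(N2N=C(c3ccc(Br)cc3)CC2c2ccc3ccccc3c2)=N1` gives 11700 nM
compound 2 `O=C1CSC(N2N=C(c3ccc(Cl)cc3)CC2c2ccc3ccccc3c2)=N1` gives 13200 nM
compound 3 `Clc1ccc(C2=NN(C3=NC(c4ccccc4)CS3)C(c3cccc4ccccc34)C2)cc1` gives 19600 nM

Compound 2 and compound 1 share one core and differ only by bromo in place of chloro on an aromatic carbon. The step is a 1.1-fold lower number from compound 2 to compound 1 (0.05 log units; within the scatter), so in this pair the exchange leaves the number essentially where it was.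

Compound 3 carries a different core; the difference between the two cores is not broken down here. Its value and those of compound 1 and compound 2 lie within the usual scatter of one another, so no ordering among the three is claimed.

Compound 4 `Brc1ccc(C2=NN(C3=NC(c4ccccc4)CS3)C(c3cccc4ccccc34)C2)cc1` is the counterpart of compound 3 with bromo in place of chloro on an aromatic carbon. The place of the exchange reads the same word for word as in the measured pair, so it is the same change, now on the second core. From compound 3 to compound 4 a step of a 1.1-fold lower number from compound 3 to compound 4 (0.04 log units; within the scatter) is expected in this assay, resting on the flat step a 1.1-fold lower number from compound 2 to compound 1 (0.05 log units; within the scatter) seen for compound 2 and compound 1. Compound 4 is estimated at 18000 nM, with a range of 9000 nM to 36000 nM.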

Compound 4, half-maximal inhibitory concentration: 17400 nM
Compound 4: middle estimate off by 1.0-fold (0.01 log units), on the high side; measured number inside the range.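

In this assay the exchange of 4-chlorophenyl to 4-bromophenyl on the core of compound 3 gives a 1.1-fold lower number from compound 3 to compound 4 (0.05 log units; within the scatter), so this pair, like the first, shows no readable effect of the exchange. Set side by side, the two steps agree: the same change on two cores in this assay, a 1.1-fold lower number (0.05 log units; within the scatter) from compound 2 to compound 1 and a 1.1-fold lower number (0.05 log units; within the scatter) from compound 3 to compound 4, 1.0-fold (0.00 log units) apart, within the scatter of two such steps. This shows that a flat result for this exchange carries over between these two cores in this assay, but it does not show that bromo and chloro are interchangeable on other cores or in other assays, and with both steps inside the scatter it gives no direction for the change.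

The compounds shown leave open whether a group other than chloro or bromo at this place, such as fluoro, methoxy, a nitrile or a carboxylic acid, would move the number beyond the scatter. Also open, from the compounds shown here alone, is whether the exchange stays flat on a core carrying an amine or a longer chain.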